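This account rests on a few compounds, and the source may have more. Where it says the series, first, only, none or still open, it means among the compounds named here.

Working notes on the series.

Of the compounds shown here, two carry measured numbers so far. Compound 1 `N#CCCSC(=S)NCc1cncs1` gives 296000 nM in a functional assay on Bel-7402 cells (Homo sapiens) for cytotoxicity, read by resazurin assay, with a stated time of 72 h; on this read-out higher numbers stand for weaker inhibition and lower numbers for stronger inhibition. Compound 2 `Fc1ccccc1-c1nnc(CCSC(=S)NCc2cccnc2)o1` gives 5540 nM in this assay, the lowest of the two numbers; the gap from compound 2 up to compound 1 lies beyond the usual scatter, so compound 2 is the stronger inhibitor of the pair on this read-out.

Compound 3 `S=C(NCc1cccnc1)SCCc1nnc(-c2cnccn2)o1` is not yet measured. It differs from compound 2 in one place: pyrazin-2-yl in place of 2-fluorophenyl on an aromatic carbon. For the measured compounds named here, no pair of measured compounds shows a step of this kind, so nothing here anchors its size or direction. The expectation is therefore a small step, not beyond the scatter, on the weaker side if any. The expected step is a 1.4-fold higher number from compound 2 to compound 3 (0.16 log units; within the scatter). For compound 3 the estimated value in this assay is 8000 nM, with a range from 2500 nM to 25000 nM.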

Compound 3, half-maximal inhibitory concentration: 1430 nM
Compound 3: the middle estimate sits 5.6-fold (0.75 log units) above what was measured; measured number outside the range, below it.
By their numbers in this assay, from the lowest: compound 3; then compound 2; then compound 1.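

For the compounds shown here, on the aromatic carbon of the five-membered ring, pyrazin-2-yl in place of 2-fluorophenyl gives a 3.9-fold lower number from compound 2 to compound 3 (0.59 log units; beyond the scatter) in this assay, the first single change whose size can be read, and it lies beyond the scatter. A carbon-only ring is therefore not required at this position: a six-membered aromatic ring with 2 hetero atoms is tolerated, and compound 3 is the stronger inhibitor of the pair. Going by these compounds alone, nothing measured so far explains why the number falls.

Going by these compounds, what an unsubstituted phenyl or a pyridin-2-yl would give at this carbon remains open, and with it whether the step follows the entry of the ring nitrogens or the departure of the fluorine. Also open, on these data alone, is how an amino group on the pyrazin-2-yl would shift the number.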